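The source may report more compounds than this note shows. Statements on the series, on what has been measured and on what is new or still open speak of the compounds shown alone.

Measured so far in a functional assay (aorta) with Rattus norvegicus as the target; a higher number here means a weaker inhibitor, a lower number a stronger inhibitor:
Compound 1 (`CCCN(CCC)CCCOc1ccc(S(=O)(=O)c2c(C)cn3ccccc23)cc1`) gives 957 nM 
Compound 2 (`CCCCc1cn2ccccc2c1S(=O)(=O)c1ccc(OCCCN(CCC)CCC)cc1`) gives 570 nM 

Compound 2 has the lower of these two numbers, but it stands within the scatter of compound 1 (a 1.7-fold lower number from compound 1 to compound 2 (0.23 log units; within the scatter)), so the two cannot be told apart here. Compound 3 (`CCCCc1cn2ccccc2c1S(=O)(=O)c1ccc(OCCCN(CCCC)CCCC)cc1`) differs from compound 2 in one place: dibutylamino in place of dipropylamino on a saturated chain carbon, three bonds along the chain from an oxygen on an aromatic ring. Within the data shown here, no measured step touches this group. Among the measured compounds shown here, the only step available, from the pair compound 1 and compound 2, concerns propyl in place of hydrogen at a different place and stayed within the scatter, so it bears on the new change only loosely. Going by these compounds, with so little to go on, no step beyond the scatter is expected in this assay, and the direction stays open. The expected change is small (a 1.1-fold lower number from compound 2 to compound 3 (0.06 log units; within the scatter)). In this assay the estimated value for compound 3 is 500 nM and the expected range runs from 170 nM up to 1500 nM (both ends estimated).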

Compound 3, half-maximal inhibitory concentration: 284 nM
The estimate for compound 3 lay 1.8-fold (0.25 log units) above the measured number; the measured number falls inside the stated range.
By their numbers in this assay, from the lowest: compounds 3, 2 and 1 (each within the scatter of the next, the first and the last beyond it).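

Among these compounds, the change from dipropylamino to dibutylamino, on a saturated chain carbon, three bonds along the chain from an oxygen on an aromatic ring, gives a 2.0-fold lower number from compound 2 to compound 3 (0.30 log units; within the scatter) in this assay and is the first measured step at this place. Among the compounds shown here, the earlier pair concerned a different place, so this step is the only reading of the amine group here, and because it stays within the scatter, compound 2 and compound 3 cannot be told apart. The result therefore shows that dibutylamino, with 9 heavy atoms against 7 for dipropylamino, can stand at this place without a step beyond the scatter, but it establishes no trend with the size of the group, and nothing measured here offers an explanation for the result. The compounds shown leave open whether a diethylamino group, a dipentylamino group or a piperidine ring at this place would move the number beyond the scatter. They also leave open whether the same exchange to dibutylamino on compound 1 would give a similar step.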